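A few compounds are considered here, and "the series" means these few. Any claim that something is new, unique, unknown or untested is made for them only; others in the source may bear on it.

Measured compounds:
- compound 1, `CCCCCCCC/C=C\CCCCCCCC(=O)OC[C@@H](COC)OP(=O)(O)OC[C@H](N)C(=O)O`: 12.9%
- compound 2, `CCCCCCCCCCCOc1ccccc1CCC(=O)O[C@H]1CCOC[C@H]1OP(=O)(O)OC[C@H](N)C(=O)O`: "not active" (no number reported)

Both were tested in an assay on HEK293 cells for agonist activity at probable G-protein coupled receptor 34 (Mus musculus), with a stated time of 1 h; on this read-out higher numbers stand for larger maximal responses and lower numbers for smaller maximal responses. Compound 1 gives 12.9%, a small maximal response. Compound 2 stands without a number at all in this assay: it is reported as "not active" (no number reported), so no size of response can be read off for it, and nothing can be said about how far it lies from compound 1.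

Compound 3, `CCCCCCCCCCCOc1ccccc1CCC(=O)O[C@@H]1CCOC[C@@H]1OP(=O)(O)OC[C@H](N)C(=O)O`, has not yet been measured. Its relation to compound 2 is the following: the two compounds have the same atoms and bonds; at least one stereo element is drawn with a configuration in one of them and without one in the other: 2 of 4 stereo elements differ; a stereocentre at a saturated ring carbon is drawn S in compound 2 and R in compound 3; a stereocentre at a saturated ring carbon is drawn R in compound 2 and S in compound 3

Among the compounds with values here, no measured pair shows what such a change does, so the direction of any step in this assay is open. A response anywhere from none to a modest one seems plausible. Compound 3 is therefore expected to give about 15% in this assay, with an estimated range from 0% to 50%.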

Compound 3, largest response reached (Emax), in percent of the reference or control that the assay uses: 8.9%
Estimate against measurement, compound 3: 6.1 percentage points above, within the range that was stated.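

Within the data shown here, compound 2 is reported as not active, with no number, so no step from it to compound 3 can be read, although compound 3 gives 8.9%. On these data alone, whether reversing the two stereocentres at saturated ring carbons changes the maximal response at all stays open.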